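Working notes on cytotoxicity from compound 1 to compound 3

The source may hold more compounds than are shown below. What is called first, only, known or untested is meant among the compounds shown, and "the series" means these compounds.

Compound 1 `Fc1ccccc1Cn1ccc2nc(-c3ccccc3)nc-2c1` has been tested in an ADME assay on MDBK cells (Bos taurus) for cytotoxicity; on this read-out higher numbers stand for lower toxicity in this test and lower numbers for higher toxicity in this test. In this assay compound 1 gives > 100000 nM, which is a limit of the assay and not a number. Compound 2 `c1ccc(-c2nc3cc[nH]cc-3n2)cc1` has also been run in this assay. In this assay compound 2 gives > 100000 nM, again a limit rather than a measured number. Going by the values given here, compound 1 therefore stands at the ceiling of what this assay reports, and the one further value shown sits at the same ceiling; the whole of the evidence is the limit of > 100000 nM in this assay, at which 2 of the 2 values shown sit. Among the compounds with values here, no step between two measured compounds can be computed from this, so nothing is known about how any structural change moves the read-out.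

Compound 3 `CC(C)N(CCn1ccc2nc(-c3ccccc3)nc-2c1)C(C)C` is the next compound for this assay. It differs from compound 1 in one place: (diisopropylamino)methyl in place of 2-fluorophenyl on a saturated chain carbon bound to an aromatic nitrogen

With both measured compounds at the ceiling, no step beyond the scatter is expected, and the step from compound 1 to compound 3 is estimated as a number no higher from compound 1 to compound 3 (the limit leaves the size open). Compound 3 is expected to give about 100000 nM in this assay, with a range from 30000 nM to 300000 nM, and most probably the assay will again report only a limit.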

Compound 3, half-maximal cytotoxic concentration: > 100000 nM
Compound 3 was reported as a limit (the forecaster's own chance of this, stated with the estimate: 75%); the middle value sits exactly at the limit.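

In this assay compound 3 gives > 100000 nM, which is a limit of the assay and not a number. Compound 1 also stands at a limit, so no step from compound 1 to compound 3 can be read: the limit of > 100000 nM in this assay, at which 3 of the 3 values shown sit.

On these data alone, whether (diisopropylamino)methyl in place of 2-fluorophenyl moves the half-maximal cytotoxic concentration at all, and how compound 1, compound 2 and compound 3 rank, remains open.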